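Chlorobutanoyl in place of bromopropanoyl on the amide

This account rests on a few compounds, and the source may have more. Where it says the series, first, only, none or still open, it means among the compounds named here.

Measured compounds:
Compound 1 `COc1cc(NCc2ccccc2)cc(OC)c1OC` — > 80000 nM in a functional assay on HCT-116 cells (Homo sapiens) for inhibition, read by MTT assay, with a stated time of 48 h; a higher number here means a weaker inhibitor, a lower number a stronger inhibitor (a limit of the assay).
Compound 2 `COc1ccc(CN(C(=O)C(C)Br)c2cc(OC)c(OC)c(OC)c2)cc1O` — 140 nM.
Compound 3 `COc1cc(NCc2cccc(O)c2)cc(OC)c1OC` — 67700 nM.

Compound 1 gives only a limit in this assay, (the limit of > 80000 nM in this assay, at which 1 of the 3 values shown sits). Compound 2, which carries an acyl group on the amide nitrogen, gives the lowest of the two numbers shown; its nearest neighbour, compound 3, sits far higher, a gap well beyond the scatter. For the measured compounds named here, the only step measured between two compounds is an at least 1.1-fold lower number from compound 1 to compound 3 (0.07 log units; that floor lies within the scatter), and that step concerns a hydroxy group on an aromatic ring, not the acyl group.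

Compound 4 `COc1ccc(CN(C(=O)CCCl)c2cc(OC)c(OC)c(OC)c2)cc1O` differs from compound 2 in the group on the carbonyl carbon: 2-chloroethyl in place of 1-bromoethyl on a carbonyl carbon. No measured step touches this part of the molecule, so there is nothing among the numbers shown that tells how large the change from compound 2 to compound 4 will be, nor in which direction. The estimate therefore rests on the value of compound 2 alone, with a wide range. Compound 4 is expected to give 2000 nM in this assay, within 200 nM to 30000 nM, which corresponds to an expected step of a 14-fold higher number from compound 2 to compound 4 (1.15 log units; beyond the scatter).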

Compound 4, half-maximal inhibitory concentration: 150 nM
For compound 4 the middle estimate is 13-fold (1.12 log units) above the measured one, and the stated range ends above it.
By their numbers in this assay, from the lowest: compounds 2 and 4 (each within the scatter of the next); then compound 3. At a limit, above all of these: compound 1.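

In this assay, 2-chloroethyl in place of 1-bromoethyl on a carbonyl carbon gives a 1.1-fold higher number from compound 2 to compound 4 (0.03 log units; within the scatter). For the compounds shown here, this is the first view of how the number responds to a change in the group on this carbonyl carbon, and here the halogen and its place on the two-carbon chain change together with no reading beyond the scatter, so compound 2 and compound 4 cannot be told apart in this assay. The change tells nothing about which of the two differences matters more, if either does, and nothing shown offers an explanation for the result.

Open, on these data alone, is how a plain propanoyl group, with no halogen at all, would read on this amide nitrogen, and whether a longer chain or an amine at the end of the chain would give a similar number. No compound shown differs from compound 2 or compound 4 only by the loss of the acyl group, so how much that group itself contributes to their low numbers also remains to be seen.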